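A Halogen Swap on the Arylidene Arm

This account rests on a few compounds, and the source may have more. Where it says the series, first, only, none or still open, it means among the compounds named here.

Of the compounds shown here, three built on one shared core have been tested in a functional assay on MIA PaCa-2 cells (Homo sapiens) for cytotoxicity, read by MTT assay, with a stated time of 72 h; on this read-out lower numbers stand for an effect already at smaller amounts and higher numbers for an effect only at larger amounts of compound. Compound 1 `COc1ccc(/C=C2\C(=O)N(c3c(Cl)cccc3Cl)c3ccccc32)cc1OC` gives 5 ug/mL. Compound 2 `O=C1/C(=C\c2cc3ccccc3nc2Cl)c2ccccc2N1c1c(Cl)cccc1Cl` gives 5 ug/mL. Compound 3 `O=C1/C(=C\c2ccc(F)cc2)c2ccccc2N1c1c(Cl)cccc1Cl` gives 5 ug/mL. Compound 3 therefore stands level with compounds 1 and 2 at the digits reported: its nearest neighbour is compound 1, with no change at the digits reported, and its furthest is compound 2, again with no change at the digits reported. All three sit within the usual scatter of one another, so no order among them can be read.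

Compound 4 `O=C1/C(=C\c2cccc(Cl)c2)c2ccccc2N1c1c(Cl)cccc1Cl` has not yet been measured in this assay. It differs from compound 3 in a single place: 3-chlorophenyl in place of 4-fluorophenyl on a double-bonded chain carbon bound to a double-bonded ring carbon. Going by the values given here, no step between two measured compounds is available to calibrate this exchange, but the three measured compounds carry different groups on that double-bonded chain carbon and still arrive at the same digits. On that basis the step of no change at the digits printed from compound 3 to compound 4 (within the scatter) is expected to be none beyond the scatter. Compound 4 is accordingly estimated to give about 5 ug/mL in this assay, with a range from 2.5 ug/mL to 10 ug/mL.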

Compound 4, concentration for half-maximal effect: 5 ug/mL
Estimate against measurement, compound 4: no gap at the digits printed, within the range that was stated.
By their numbers in this assay, from the lowest: compounds 1, 2, 3 and 4 (each within the scatter of the next).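

In this assay, going by these compounds alone, replacing 4-fluorophenyl with 3-chlorophenyl on a double-bonded chain carbon bound to a double-bonded ring carbon gives no change at the digits printed from compound 3 to compound 4 (within the scatter), the first step that can be read at this position. The two groups match in the counts computed for them, and the exchange alters both the halogen and its place on the phenyl ring, so this single step cannot separate those two changes; it shows only that, taken together, they leave the value within the scatter. No measurement is available that would explain this result.

All four compounds shown carry an aromatic group at this position and share the rest of the core, so they do not show how far the value would hold with an amine, a carboxylic acid or a longer chain in its place. They also leave open whether the same exchange of 4-fluorophenyl for 3-chlorophenyl would remain within the scatter on a core with different groups elsewhere.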